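Swapping an aryl group: one step from compound 2

The source may report more compounds than this note shows. Statements on the series, on what has been measured and on what is new or still open speak of the compounds shown alone.

Measured so far:
compound 1, `CCCCc1ccc2c(c1)C(=O)C(=O)N2`, in a functional assay on K562 cells (Homo sapiens) for antiproliferative activity, read by MTT assay, with a stated time of 48 h (on this read-out lower numbers stand for stronger inhibition and higher numbers for weaker inhibition), reaches only the assay limit, > 10000 nM.
compound 2, `COc1ccc(CN2C(=O)C(=O)c3cc(-c4cccc(OC)c4)ccc32)cc1`, in this assay gives 100 nM.

Compound 1 stands at a limit of this assay rather than at a number. Compound 2 therefore holds the only number shown; the other value is the limit (the limit of > 10000 nM in this assay, at which 1 of the 2 values shown sits), at which one of the two values sits. Going by the values given here, with this single number there is no measured step between compounds that differ in one place, so the size of any change cannot be read from the data.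

Compound 3, `COc1ccc(CN2C(=O)C(=O)c3cc(-c4ccc5ccccc5c4)ccc32)cc1`, has not been measured in this assay. Relative to compound 2 it changes in one way: naphthalen-2-yl in place of 3-methoxyphenyl on an aromatic carbon. Among the compounds with values here, because no measured step is available, the expected size of the change in this assay is taken from the structural change alone. The step from compound 2 to compound 3 is expected to be small, within the scatter or at most a modest weakening, a 1.5-fold higher number from compound 2 to compound 3 (0.18 log units; within the scatter). Compound 3 is accordingly estimated at 150 nM, with a range of 40 nM to 600 nM.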

Compound 3, half-maximal inhibitory concentration: 340 nM
The estimate for compound 3 lay 2.3-fold (0.36 log units) below the measured number; the range from low to high includes it.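

In this assay, going by these compounds alone, putting naphthalen-2-yl in place of 3-methoxyphenyl gives a 3.4-fold higher number from compound 2 to compound 3 (0.53 log units; beyond the scatter) and so provides the only step that can be read at this position on the shared core. The step is modest but lies beyond the scatter, which shows that the number responds to the aryl group carried here, though not steeply for this exchange. Compound 3 also still gives a measured number rather than a limit of the assay, so this aromatic carbon can carry a group of two six-membered aromatic rings of carbon only and keep measurable antiproliferative activity, and nothing shown here accounts for the size of the step.

This single exchange removes the methoxy group and adds a second ring together, so the compounds shown leave open which of the two changes matters, and a plain phenyl group at the same place would separate them. Also open, on these data alone, is how this assay would respond to an aryl group bearing a dimethylamino group or a carboxylic acid at this position, or to a pyridine ring in place of the aryl ring.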